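This account rests on a few compounds, and the source may have more. Where it says the series, first, only, none or still open, it means among the compounds named here.

Measured compounds in a functional assay on THP-1 cells (Homo sapiens) for inhibition, read by sulforhodamine B assay, tested at 100 uM; a higher number here means more inhibition of growth at the concentration tested, a lower number less inhibition of growth:
- compound 1 `COc1cc(C2CC(c3cccc4ccccc34)=NN2C(C)=O)ccc1OCc1cn(Cc2ccc([N+](=O)[O-])cc2)nn1`: 79%
- compound 2 `COc1cc(C2CC(c3ccc([N+](=O)[O-])cc3)=NN2C(C)=O)ccc1OCc1cn(Cc2ccc([N+](=O)[O-])cc2)nn1`: 59%
- compound 3 `COc1cc(C2CC(c3ccc(Br)cc3)=NN2C(C)=O)ccc1OCc1cn(Cc2ccc([N+](=O)[O-])cc2)nn1`: 23%

Compound 1 stands highest of the three numbers. Compound 2 comes nearest, a number 20 percentage points lower from compound 1 to compound 2 (beyond the scatter); compound 3 lies furthest, a number 56 percentage points lower from compound 1 to compound 3 (beyond the scatter). Between those two, a number 36 percentage points lower from compound 2 to compound 3 (beyond the scatter).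

Compound 4 `COc1cc(C2CC(c3ccc(Cl)cc3)=NN2C(C)=O)ccc1OCc1cn(Cc2ccc([N+](=O)[O-])cc2)nn1` is not yet measured in this assay. Relative to compound 1 the change is 4-chlorophenyl in place of naphthalen-1-yl on a carbon with a double bond to nitrogen.

Going by the values given here, the step that bears most directly on this change is the one from compound 1 to compound 3, where a 4-bromophenyl replaced the same naphthalen-1-yl at the same carbon with a double bond to nitrogen and gave a large drop. The step from compound 1 to compound 2 also replaced the naphthalen-1-yl there, but with a 4-nitrophenyl, and gave only a modest drop; compound 2 and compound 3 then differ by bromo in place of nitro, with a further large drop. A 4-chlorophenyl is nearer in kind to the 4-bromophenyl of compound 3 than to the 4-nitrophenyl of compound 2, so a large drop beyond the scatter is expected in this assay, of roughly the size seen for compound 3. The estimate for compound 4 is 28%, with a range from 10% to 50%. The expected step is a number 51 percentage points lower from compound 1 to compound 4 (beyond the scatter).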

Compound 4, percent growth inhibition at one concentration: 37%
For compound 4 the middle estimate is 9 percentage points below the measured one, within the range that was stated.
By their numbers in this assay, from the lowest: compound 3; then compound 4; then compound 2; then compound 1.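

In this assay the change to 4-chlorophenyl gives a number 42 percentage points lower from compound 1 to compound 4 (beyond the scatter) and is now the third replacement of naphthalen-1-yl by a 4-substituted phenyl to fall beyond the scatter, so among the compounds shown, compound 1 alone keeps the highest number. The group at the 4-position of the phenyl also counts, even between two halogens: chloro in place of bromo gives a number 14 percentage points higher from compound 3 to compound 4 (beyond the scatter) while chloro in place of nitro gives a number 22 percentage points lower from compound 2 to compound 4 (beyond the scatter) and places compound 4 between the other two phenyl compounds. Nothing available explains these differences at this position.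

Whether the gain belongs to the fused naphthalen-1-yl itself stays open, as the shown set holds neither naphthalen-2-yl nor unsubstituted phenyl, and the effect of a 4-amino, 4-methoxy or 4-carboxylic acid group on the phenyl is likewise unknown. The read-out is growth inhibition at a single concentration, so it leaves open whether the same order would hold across a range of concentrations.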